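The source may hold more compounds than are shown below. What is called first, only, known or untested is meant among the compounds shown, and "the series" means these compounds.

In a functional assay on NCI-H1975 cells (Homo sapiens) for cytotoxicity, read by MTT assay, with a stated time of 72 h (a higher number here means a weaker inhibitor, a lower number a stronger inhibitor), compound 1 (`COc1ccc(/C=C2\CNC/C(=C\c3ccc(OC)c(OC)c3)C2=O)cc1OC`) gives 10300 nM and compound 3 (`CCN1C/C(=C\c2ccc(OC)c(OC)c2)C(=O)/C(=C/c2ccc(OC)c(OC)c2)C1`) gives 8500 nM. Compound 2 (`COc1cc(/C=C2\CN(C)C/C(=C\c3cc(OC)c(OC)c(OC)c3)C2=O)cc(OC)c1OC`) has the lowest number of the three, at 1000 nM. Compound 4 (`COc1cc(/C=C2\CN(C(=O)C(C)C)C/C(=C\c3cc(OC)c(OC)c(OC)c3)C2=O)cc(OC)c1OC`) carries isopropylcarbonyl in place of methyl on an amine nitrogen in a ring. Among the measured compounds shown here, one measured step bears on this place, a 1.2-fold lower number from compound 1 to compound 3 (0.08 log units; within the scatter), which lies within the scatter. For the measured compounds named here, that step brings in ethyl, and no measured compound has a carbonyl group on this nitrogen, so the evidence is thin. No step beyond the scatter is therefore expected in this assay. The expected step is a 1.4-fold lower number from compound 2 to compound 4 (0.15 log units; within the scatter). Compound 4 is estimated at 700 nM, with an expected range of 200 nM to 2500 nM.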

Compound 4, half-maximal inhibitory concentration: 1900 nM
Beside the measured number, compound 4's estimate is 2.7-fold (0.43 log units) below it, and the stated range covers the measured number.
By their numbers in this assay, from the lowest: compounds 2 and 4 (each within the scatter of the next); then compounds 3 and 1 (each within the scatter of the next).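

In this assay, isopropylcarbonyl in place of methyl on an amine nitrogen in a ring gives a 1.9-fold higher number from compound 2 to compound 4 (0.28 log units; within the scatter). Among the compounds shown here, this is the first measured carbonyl group on this nitrogen, and the number stays within the scatter, as it did with ethyl in a 1.2-fold lower number from compound 1 to compound 3 (0.08 log units; within the scatter). No measurement shown here accounts for this result.

The compounds shown leave open whether a benzoyl group, a carboxylic acid or a longer chain on this nitrogen would also leave the number within the scatter. They also leave open whether isopropylcarbonyl would behave the same way on the core of compound 1.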